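Imidazolylpropyl Amide on a Shared Sulfonamide Core

The source may report more compounds than this note shows. Statements on the series, on what has been measured and on what is new or still open speak of the compounds shown alone.

Of the compounds shown here, three built on one shared core have been measured in a functional assay on CHO cells for antagonist activity at 5-hydroxytryptamine receptor 6 (Homo sapiens), read by FLIPR; a lower number here means a stronger inhibitor, a higher number a weaker inhibitor. Compound 2 `COc1ccc(S(=O)(=O)N2CC(C(=O)N3CC(CN)C3)c3ccccc32)c2ccccc12` gives 79.4 nM. Compound 3 `CCN(CC)CCCNC(=O)C1CN(S(=O)(=O)c2ccc(OC)c3ccccc23)c2ccccc21` gives 79.4 nM, and the step of no change at the digits printed from compound 2 to compound 3 (within the scatter) shows that exchanging the amide substituent leaves the number unchanged. Compound 1 `COc1ccc(S(=O)(=O)N2CC(C(=O)NC3CCN(Cc4ccccc4)CC3)c3ccccc32)c2ccccc12` gives 50.1 nM, within the scatter of compound 2, so compound 2 stands level with compound 3 and all three numbers lie within the scatter of one another. Compound 4 `COc1ccc(S(=O)(=O)N2CC(C(=O)NCCCn3ccnc3)c3ccccc32)c2ccccc12` carries (3-(1H-imidazol-1-yl)propyl)amino in place of 3-(aminomethyl)azetidin-1-yl on a carbonyl carbon. Among the compounds with values here, the only measured step bearing on this position is the one from compound 2 to compound 3, which was flat, so a change at the amide substituent has so far not moved the number. Compound 4 is therefore expected to give 100 nM, within 40 nM to 250 nM, a step of a 1.3-fold higher number from compound 2 to compound 4 (0.10 log units; within the scatter) that is estimated to stay within the scatter.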

Compound 4, inhibition constant: 79.4 nM
The estimate for compound 4 lay 1.3-fold (0.10 log units) above the measured number; the range from low to high includes it.
By their numbers in this assay, from the lowest: compounds 1, 2, 3 and 4 (each within the scatter of the next).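

Placing (3-(1H-imidazol-1-yl)propyl)amino on the carbonyl carbon gives no change at the digits printed from compound 2 to compound 4 (within the scatter) in this assay, so a five-membered aromatic ring now joins the substituents at this position that leave the number level. Exchanging only the chain end, 1H-imidazol-1-yl in place of diethylamino, gives no change at the digits printed from compound 3 to compound 4 (within the scatter) and shows the same flatness for that narrower change. Nothing available accounts for this flatness. From the compounds shown here alone, it remains open whether a carboxylic acid at the chain end, or a longer chain, would leave the number level too.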